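Lengthening the amine-bearing chain on the pentyloxy flavone

The source may report more compounds than this note shows. Statements on the series, on what has been measured and on what is new or still open speak of the compounds shown alone.

The three measured compounds share one core, carrying a trimethoxyphenyl group and an oxygen-linked chain of varying length and end group. Compound 1 `CCOc1c(-c2cc(OC)c(OC)c(OC)c2)oc2ccccc2c1=O` has the shortest chain; in a functional assay on DU-145 cells (Homo sapiens) for antiproliferative activity, read by WST assay, with a stated time of 3 days (a lower number here means a stronger inhibitor, a higher number a weaker inhibitor), compound 1 gives 6200 nM. Compound 2 `CCCCCOc1c(-c2cc(OC)c(OC)c(OC)c2)oc2ccccc2c1=O` carries a plain pentyl chain. In this assay compound 2 reaches only the limit > 50000 nM, so it sits at the weak end of the numbers shown, with an at least 8.0-fold higher number from compound 1 to compound 2 (0.90 log units; beyond the scatter). Compound 3 `CCCCCN(CCCCC)CCCOc1c(-c2cc(OC)c(OC)c(OC)c2)oc2ccccc2c1=O` ends its chain in a dipentylamino group, and in this assay compound 3 gives 12300 nM; this amounts to a 2.0-fold higher number from compound 1 to compound 3 (0.30 log units; within the scatter) and to an at least 4.0-fold lower number from compound 2 to compound 3 (0.60 log units; beyond the scatter).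

Compound 4 `CCCCCN(CCCCC)CCCCCOc1c(-c2cc(OC)c(OC)c(OC)c2)oc2ccccc2c1=O` is compound 2 with the change (dipentylamino in place of hydrogen on a saturated chain carbon, five bonds along the chain from an oxygen on an aromatic ring). The step from compound 2 to compound 3 is the closest comparison, since it also brings the dipentylamino end onto a chain of the shared core and gave an at least 4.0-fold lower number from compound 2 to compound 3 (0.60 log units; beyond the scatter); the step from compound 1 to compound 3 showed that adding the amine end to a shorter chain changed little. Compound 4 is therefore expected to show a step of an at least 2.5-fold lower number from compound 2 to compound 4 (0.39 log units; beyond the scatter) in this assay, toward a stronger inhibitor. Compound 4 is estimated at 20000 nM, within 6000 nM to 60000 nM.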

Compound 4, half-maximal inhibitory concentration: 11700 nM
Compound 4: middle estimate off by 1.7-fold (0.23 log units), on the high side; low and high end bracket the measured number.
By their numbers in this assay, from the lowest: compounds 1, 4 and 3 (each within the scatter of the next). At a limit, above all of these: compound 2.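

Compound 4 shows that the drop seen when dipentylamino ends a chain is not tied to the shorter chain of compound 3: on a saturated chain carbon, five bonds along the chain from an oxygen on an aromatic ring, the same group gives an at least 4.2-fold lower number from compound 2 to compound 4 (0.63 log units; beyond the scatter) on the pentyl chain too. In this assay compound 3 gives 12300 nM and compound 4 gives 11700 nM and these two values lie within the scatter of each other, so moving the amine end out along the chain makes no difference that can be read here. As far as these compounds go, compound 2 stands at a limit and not at a number, so the true size of this step stays unknown and only its lower bound can be read: the limit of > 50000 nM in this assay, at which 1 of the 4 values shown sits.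

The compounds shown leave open whether the pentyl arms on the nitrogen matter, since a smaller amine such as dimethylamino or a ring amine such as piperidine could behave differently at the same chain end. They also leave open whether a carboxylic acid there, or a still longer chain carrying dipentylamino, would keep this level of activity.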